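Replacing 3-hydroxypropyl with allyl in compound 1

The source may hold more compounds than are shown below. What is called first, only, known or untested is meant among the compounds shown, and "the series" means these compounds.

Measured in a functional assay on HL-60 cells (Homo sapiens) for cytotoxicity, read by MTT assay, with a stated time of 24 h; a lower number here means a stronger inhibitor, a higher number a weaker inhibitor:
- Compound 1 `OCCCOc1c(Br)cc(Br)cc1Oc1ccc(Br)cc1Br`: 29.9 ug/mL
- Compound 2 `Cc1ccc(S(=O)(=O)n2nc(N3CCN(CCCCCOc4c(Br)cc(Br)cc4Oc4ccc(Br)cc4Br)CC3)c3cc([N+](=O)[O-])ccc32)cc1`: 52.5 ug/mL

Only these two compounds have been measured, and their numbers lie within the usual scatter of each other, so compound 1 cannot be ranked apart from compound 2. Compound 3 `C=CCOc1c(Br)cc(Br)cc1Oc1ccc(Br)cc1Br` has not yet been measured. It keeps the core of compound 1 and carries vinyl in place of 2-hydroxyethyl on a saturated chain carbon bound to an oxygen on an aromatic ring. Within the data shown here, no measured pair isolates this change. Even with a far larger structural difference, compound 2 gives 52.5 ug/mL, still within the scatter of compound 1 at 29.9 ug/mL. No step beyond the scatter is therefore expected in this assay, in either direction. The expected step is a 1.0-fold higher number from compound 1 to compound 3 (0.00 log units; within the scatter). For compound 3 the estimated value is 30 ug/mL, with an expected range from 13 ug/mL to 70 ug/mL.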

Compound 3, half-maximal inhibitory concentration: 27.9 ug/mL
Beside the measured number, compound 3's estimate is 1.1-fold (0.03 log units) above it; low and high end bracket the measured number.
By their numbers in this assay, from the lowest: compounds 3, 1 and 2 (each within the scatter of the next).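

In this assay, among these compounds, this pair is the first to isolate the change, and it gives a 1.1-fold lower number from compound 1 to compound 3 (0.03 log units; within the scatter) on the shared core. Exchanging 3-hydroxypropyl for allyl therefore leaves the number within the scatter, even though the leaving 2-hydroxyethyl carries 1 hydrogen-bond donor and 1 hydrogen-bond acceptor and the entering vinyl carries neither. No measurement available here explains why the two compounds read alike.

The compounds shown leave open whether an amine, a carboxylic acid or a longer chain on the saturated chain carbon bound to an oxygen on an aromatic ring would also stay within the scatter of compound 1. They also leave open whether the exchange of 3-hydroxypropoxy for allyloxy would read the same way on any other core.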